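The source may hold more compounds than are shown below. What is called first, only, known or untested is meant among the compounds shown, and "the series" means these compounds.

Of the compounds shown here, three built on one shared core have been measured in an assay on blood for inhibition of C-X-C chemokine receptor type 3 (Homo sapiens), with a stated time of 30 min; a higher number here means a weaker inhibitor, a lower number a stronger inhibitor. Compound 1 `COc1ncc(-c2nc(C(F)(F)F)sc2N2CCN(C(=O)Cn3nc(C)nc3C)[C@H](C)C2)cn1` gives 1040 nM. Compound 2 `CCc1ncc(-c2nc(C(F)(F)F)sc2N2CCN(C(=O)Cn3nc(C)nc3C)[C@H](C)C2)cn1` gives 567 nM, and compound 3 `Cc1nc(C)n(CC(=O)N2CCN(c3sc(C(F)(F)F)nc3-c3cnc(C4CC4)nc3)C[C@H]2C)n1` gives 674 nM. Of these three numbers compound 3 holds the second highest, with compound 2 nearest and compound 1 furthest, yet both gaps lie within the scatter, so no real order among the three can be read from them.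

Compound 4 `CCOc1ccc(-c2nc(C(F)(F)F)sc2N2CCN(C(=O)Cn3nc(C)nc3C)[C@H](C)C2)cn1` has not yet been measured. The change is 6-ethoxypyridin-3-yl in place of 2-cyclopropylpyrimidin-5-yl on an aromatic carbon. The measured steps that bear on this all alter the group on that same aromatic carbon: a 1.8-fold lower number from compound 1 to compound 2 (0.26 log units; within the scatter), a 1.5-fold lower number from compound 1 to compound 3 (0.19 log units; within the scatter) and a 1.2-fold higher number from compound 2 to compound 3 (0.08 log units; within the scatter). None of them moved the number beyond the scatter. For the measured compounds named here, the present change is larger, since the whole aromatic ring is exchanged together with the group carried on it, but no measured step speaks for a move in either direction. The step is therefore expected to be small: a 1.0-fold higher number from compound 3 to compound 4 (0.02 log units; within the scatter). The estimate for compound 4 is 700 nM, within a range from 300 nM to 1600 nM.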

Compound 4, half-maximal inhibitory concentration: 887 nM
For compound 4 the middle estimate is 1.3-fold (0.10 log units) below the measured one; measured number inside the range.
By their numbers in this assay, from the lowest: compounds 2, 3, 4 and 1 (each within the scatter of the next).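

In this assay, exchanging the whole aromatic ring on this carbon, and not only the group it carries, still gives no step beyond the scatter: 6-ethoxypyridin-3-yl gives a 1.3-fold higher number from compound 3 to compound 4 (0.12 log units; within the scatter) and a 1.6-fold higher number from compound 2 to compound 4 (0.19 log units; within the scatter) and also a 1.2-fold lower number from compound 1 to compound 4 (0.07 log units; within the scatter) in the three comparisons. Within these four compounds, then, a six-membered aromatic ring with 1 hetero atom can stand at this position in place of one with 2 hetero atoms without a readable shift in the number, although the ring and its group change together here, so their separate contributions cannot be told apart. No measurement at hand offers an explanation for these numbers.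

On these data alone, whether any group at this position moves the number beyond the scatter remains open. An amine or a carboxylic acid on this ring, or a longer chain such as butoxy, could test that.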